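Replacing morpholin-4-yl with (oxetan-3-yl)amino

The source may report more compounds than this note shows. Statements on the series, on what has been measured and on what is new or still open speak of the compounds shown alone.

Within the data shown here, in a functional assay on HCT-116 cells (Homo sapiens) for antiproliferative activity, read by MTT assay, with a stated time of 72 h (a lower number here means a stronger inhibitor, a higher number a weaker inhibitor), compound 2 `C=CC(=O)N(CC(=O)N1CCOCC1)c1nc(-c2ccccc2)cs1` gives 14600 nM, the only actual number so far. Compound 1 `C=CC(=O)N(CC(=O)NC1CCCCC1)c1nc(-c2ccccc2)cs1` gives >= 29300 nM, which is a limit of the assay and not a number. Among the measured compounds shown here, the sole measured step, an at least 2.0-fold lower number from compound 1 to compound 2 (0.30 log units; that floor lies within the scatter), changes the same group on the carbonyl carbon that changes next.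

Compound 3 `C=CC(=O)N(CC(=O)NC1COC1)c1nc(-c2ccccc2)cs1` differs from compound 2 as follows: (oxetan-3-yl)amino in place of morpholin-4-yl on a carbonyl carbon. Like the cyclohexylamino of compound 1, the entering group is an amino group on that carbonyl carbon. For the measured compounds named here, the step of an at least 2.0-fold lower number from compound 1 to compound 2 (0.30 log units; that floor lies within the scatter) is therefore the only guide, read here in reverse, and it suggests a small move towards a higher number in this assay, possibly none beyond the scatter. The expected change is a 1.4-fold higher number from compound 2 to compound 3 (0.14 log units; within the scatter). The estimate for compound 3 is 20000 nM, with an expected range of 8000 nM to 45000 nM.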

Compound 3, half-maximal inhibitory concentration: 20800 nM
For compound 3 the middle estimate is 1.0-fold (0.02 log units) below the measured one; low and high end bracket the measured number.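

In this assay, (oxetan-3-yl)amino in place of morpholin-4-yl on the carbonyl carbon gives a 1.4-fold higher number from compound 2 to compound 3 (0.15 log units; within the scatter), so these two groups cannot be told apart at this position, and compound 3 supplies a second actual number for the series. Oxetan-3-yl in place of cyclohexyl on the amide-type nitrogen gives an at least 1.4-fold lower number from compound 1 to compound 3 (0.14 log units; that floor lies within the scatter), a first comparison of two rings on that nitrogen, and this floor does not separate them. Compound 1 stands at a limit of the assay, not at a number, so the full size of that step cannot be read: the limit of >= 29300 nM in this assay, at which 1 of the 3 values shown sits.

As far as these compounds go, whether any group on this carbonyl carbon can move the number beyond the scatter remains open. A piperazin-1-yl ring, a dimethylamino group or a carboxylic acid on a longer chain would each test this.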